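Replacing Cyclohexyl with 4-Fluorophenyl: An Expected Antiproliferative Value

The source may report more compounds than this note shows. Statements on the series, on what has been measured and on what is new or still open speak of the compounds shown alone.

Compound 1 `C#CCOC(=O)C[C@@H]1C(C(=O)OC)=CO[C@@H](O[C@@H]2O[C@H](COC(C)=O)[C@@H](OC(C)=O)[C@H](OC(C)=O)[C@H]2OC(C)=O)/C1=C/C`: > 15000 nM
Compound 2 `C/C=C1/[C@H](O[C@@H]2O[C@H](CO)[C@@H](O)[C@H](O)[C@H]2O)OC=C(C(=O)OC)[C@H]1CC(=O)OCCC1CCCCC1`: 2000 nM

Among the measured compounds shown here, in a functional assay on SK-BR-3 cells (Homo sapiens) for antiproliferative activity, read by MTT assay, with a stated time of 72 h (a lower number here means a stronger inhibitor, a higher number a weaker inhibitor), compound 2 gives 2000 nM, the only exact number so far. Compound 1 is reported as > 15000 nM, which is a limit of the assay and not a number.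

Compound 3 `C/C=C1/[C@H](O[C@@H]2O[C@H](CO)[C@@H](O)[C@H](O)[C@H]2O)OC=C(C(=O)OC)[C@H]1CC(=O)OCCc1ccc(F)cc1` has not yet been measured. It keeps the rest of compound 2 and differs from it in one place: 4-fluorophenyl in place of cyclohexyl on a saturated chain carbon, two bonds along the chain from an oxygen next to a carbonyl group. Here, 4-fluorophenyl stands in place of cyclohexyl on a saturated chain carbon, two bonds along the chain from an oxygen next to a carbonyl group.

For the measured compounds named here, no measured pair of compounds shows what this change does, so the expectation is loose. With compound 2 at 2000 nM as the sole anchor, no step beyond the scatter is expected in this assay, with a slight lean towards a higher number. The expected change is a 1.5-fold higher number from compound 2 to compound 3 (0.18 log units; within the scatter). The estimated value for compound 3 is 3000 nM, with an expected range of 1000 nM to 10000 nM.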

Compound 3, half-maximal inhibitory concentration: > 20000 nM
Compound 3: no number, only a limit; the forecaster's own chance of this, stated with the estimate: 15%; middle value at least 6.6-fold (0.82 log units) away from the limit.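

In this assay compound 3 gives > 20000 nM, which is a limit of the assay and not a number. Among the compounds shown here, the change of 4-fluorophenyl in place of cyclohexyl on a saturated chain carbon, two bonds along the chain from an oxygen next to a carbonyl group, is read as an at least 10-fold higher number from compound 2 to compound 3 (1.00 log units; beyond the scatter), the first comparison of two compounds that differ in one place, and it shows that the group held here is not indifferent in this assay, with the cyclohexyl form the only one of the pair to give an exact number. The true size of the step cannot be read, only its lower bound, and the comparison rests on a limit: the limit of > 20000 nM in this assay, at which 1 of the 3 values shown sits.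

The compounds shown leave open whether the difference goes with the aromatic ring or with the fluorine, as the two enter together in this single replacement. An unsubstituted phenyl on the same chain would separate the two, and a cyclohexyl on a longer chain or an amine in its place would show how far the activity of the cyclohexyl form extends, with compound 2 at 2000 nM as the reference point.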